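The source may report more compounds than this note shows. Statements on the series, on what has been measured and on what is new or still open speak of the compounds shown alone.

Measured in a functional assay on MCF7 cells (Homo sapiens) for cytotoxicity, read by sulforhodamine B assay, with a stated time of 72 h; on this read-out higher numbers stand for weaker inhibition and lower numbers for stronger inhibition:
- compound 1 `Cc1ccccc1NC(=O)Nc1ccc(Nc2ncnc3c2cnn3-c2ccc(Cl)cc2)cc1` gives 3150 nM
- compound 2 `Clc1ccc(COc2ccc(Nc3ncnc4c3cnn4-c3ccccc3)cc2)cc1` gives 4360 nM
- compound 3 `Clc1ccc(COc2ccc(Nc3ncnc4c3cnn4-c3ccc(Cl)cc3)cc2)cc1` gives > 100000 nM (a limit, not a number)

Compound 3 therefore has no exact value and sits at the limit (the limit of > 100000 nM in this assay, at which 1 of the 3 values shown sits). Compound 4 `O=C(Nc1ccccc1Cl)c1ccc(Nc2ncnc3c2cnn3-c2ccc(Cl)cc2)cc1` has (2-chlorophenyl)carbamoyl in place of (4-chlorobenzyl)oxy on an aromatic carbon, para to a large group ((2-chlorophenyl)carbamoyl in place of (4-chlorobenzyl)oxy on an aromatic carbon).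

Two measured steps lead into compound 3, and both were large and beyond the scatter. Putting (4-chlorobenzyl)oxy in place of ((2-methylphenyl)carbamoyl)amino gave one of them (an at least 31-fold higher number from compound 1 to compound 3 (1.50 log units; beyond the scatter)). Putting chloro in place of hydrogen on an aromatic carbon gave the other (an at least 22-fold higher number from compound 2 to compound 3 (1.36 log units; beyond the scatter)). The first is the closer guide, as compound 4 also loses the (4-chlorobenzyl)oxy group. Compound 4 keeps that chloro and shares a carbamoyl unit with compound 1, which gives a measured value (3150 nM). Within the data shown here, the incoming group still differs from the one in compound 1, so the guide is imperfect, and another limit in this assay cannot be ruled out.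

A large move towards stronger inhibition is therefore expected (an at least 12-fold lower number from compound 3 to compound 4 (1.09 log units; beyond the scatter)). The estimated value for compound 4 is 8000 nM, with an expected range from 2000 nM to 40000 nM.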

Compound 4, half-maximal inhibitory concentration: > 100000 nM
Compound 4: no number, only a limit; the forecaster's own chance of this, stated with the estimate: 15%; middle value at least 12-fold (1.09 log units) away from the limit.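

In this assay, compound 4 gives a limit and not a number, just as compound 3 does: the limit of > 100000 nM in this assay, at which 2 of the 4 values shown sit.

The step between these two compounds therefore cannot be read, and with (2-chlorophenyl)carbamoyl in place of (4-chlorobenzyl)oxy, no measurable inhibition comes into view. What is new is that sharing a carbamoyl unit with compound 1 is not enough: (2-chlorophenyl)carbamoyl in place of ((2-methylphenyl)carbamoyl)amino gives an at least 31-fold higher number from compound 1 to compound 4 (1.50 log units; beyond the scatter), so of the three compounds carrying the chloro on the shared core, only compound 1 gives a number.

Compound 4 differs from compound 1 in two ways within this one group, with chloro in place of methyl on its ring and a different link to the core, and the compounds shown cannot separate these two changes. They also leave open how a small group such as an amine or a carboxylic acid would behave at this place, and whether ((2-methylphenyl)carbamoyl)amino would still give a number without the chloro on the core.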